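Replacing (pyridin-2-yl)methyl with tert-butyl on compound 1

The source may report more compounds than this note shows. Statements on the series, on what has been measured and on what is new or still open speak of the compounds shown alone.

- compound 1 `O=C(NCc1cc(Cl)ccc1-n1cnnn1)[C@@H]1[C@@H]2C[C@@H]2CN1C(=O)[C@H](O)Cc1ccccn1` at 0.62 10^-6 cm/s
- compound 2 `CC1(C[C@@H](O)C(=O)N2N=CC[C@H]2C(=O)NCc2cc(Cl)ccc2-n2cnnn2)CC1` at 9.5 10^-6 cm/s
- compound 3 `CC(C)(C)C[C@@H](O)C(=O)N1[C@@H]2C[C@@H]2C[C@H]1C(=O)NCc1cc(Cl)ccc1-n1cnnn1` at 24 10^-6 cm/s

In an ADME assay on Caco-2 cells (Homo sapiens) for permeability, read by LC-MS, in the apical to basolateral direction, with a stated time of 60 min, at pH 6.5 (a lower number here means that the compound crosses the layer more slowly, a higher number that the compound crosses the layer faster), compound 1 gives 0.62 10^-6 cm/s as the lowest of the three numbers, and the other two compounds both stand above it, beyond the usual scatter. Compound 4 `CC(C)(C)[C@@H](O)C(=O)N1C[C@H]2C[C@H]2[C@H]1C(=O)NCc1cc(Cl)ccc1-n1cnnn1` has not been measured yet. It keeps the core of compound 1 and differs in one place. The change is tert-butyl in place of (pyridin-2-yl)methyl on a saturated chain carbon bound to a carbonyl carbon and an oxygen on a saturated carbon and, in words, tert-butyl in place of (pyridin-2-yl)methyl on a saturated chain carbon bound to a carbonyl carbon and an oxygen on a saturated carbon.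

For the measured compounds named here, no two measured compounds differ in only one place, so this change has never been seen alone. Compound 2 at 9.5 10^-6 cm/s and compound 3 at 24 10^-6 cm/s both lack the (pyridin-2-yl)methyl group, but they also differ from compound 1 elsewhere, so the comparison is loose. In this assay a rise beyond the scatter is therefore expected, an estimated 23-fold higher number from compound 1 to compound 4 (1.35 log units; beyond the scatter) in size. For compound 4 the estimated value is 14 10^-6 cm/s with an expected range of 5 10^-6 cm/s to 35 10^-6 cm/s in this measurement.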

Compound 4, apparent permeability: 3.8 10^-6 cm/s
Beside the measured number, compound 4's estimate is 3.7-fold (0.57 log units) above it; the whole stated range lies above it.
By their numbers in this assay, from the lowest: compound 1; then compound 4; then compound 2; then compound 3.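

In this assay, for the compounds shown here, the core of compound 1 is kept and only one group changes, so this position can be read on its own for the first time: tert-butyl in place of (pyridin-2-yl)methyl gives a 6.1-fold higher number from compound 1 to compound 4 (0.79 log units; beyond the scatter). This single change is therefore enough to move the number upward beyond the scatter. The group that leaves has a six-membered aromatic ring and a hydrogen-bond acceptor, and tert-butyl has neither, but no available measurement explains the rise.

Going by these compounds, it remains open whether the whole ring or only its nitrogen matters, and a benzyl group at this place would separate the two. Also open, on these data alone, is whether a longer chain or an amine here would shift the number in the same direction, or whether the step would hold on a different core.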